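From a Methyl to an Ethyl Group at the Assay Limit

The compounds below may be only part of what the source reports. "The series", "measured", "known", "first", "only" and "open" are said of these compounds alone.

Compound 1 `Cc1ccc(S(=O)(=O)Nc2ccc(-c3nc4ccccc4o3)cc2)cc1` was tested in an assay on isolated protein for inhibition of malate dehydrogenase, mitochondrial (Sus scrofa), with stated times of 45 min and 30 min (on this read-out lower numbers stand for stronger inhibition and higher numbers for weaker inhibition), and returned only a limit of > 63000 nM. Compound 2 `COc1cccc(S(=O)(=O)Nc2ccc3oc(-c4ccccc4)nc3c2)c1` likewise returned a limit of > 63000 nM in this assay. Compound 3 `O=S(=O)(Nc1ccc2oc(-c3ccccc3)nc2c1)c1cccc(Cl)c1` also returned a limit of > 63000 nM. Going by the values given here, the one step among measured compounds, a step that the two limits leave unreadable from compound 2 to compound 3, has no readable size, since the limit of > 63000 nM in this assay, at which 3 of the 3 values shown sit, holds all three values. Compound 4 `CCc1ccc(S(=O)(=O)Nc2ccc(-c3nc4ccccc4o3)cc2)cc1` differs from compound 1 by methyl in place of hydrogen on a saturated chain carbon bound to an aromatic carbon, turning 4-methylphenyl into 4-ethylphenyl. Among the compounds with values here, no measured step bears on this change, and compound 1 itself sits only at the limit, which leaves no basis for expecting a shift beyond the scatter. Compound 4 is therefore expected to remain at or near the limit. The estimate for compound 4 is 100000 nM, between 30000 nM and 400000 nM, an expected step that the limit leaves unreadable from compound 1 to compound 4.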

Compound 4, half-maximal inhibitory concentration: > 63000 nM
Compound 4 gave a limit, no number; the forecaster's own chance of this, stated with the estimate: 85%; the middle value lies beyond the limit too.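

No step can be read from compound 1 to compound 4, since both gave only a limit in this assay: the limit of > 63000 nM in this assay, at which 4 of the 4 values shown sit. The compounds shown leave open which structural change, if any, would give a measurable value in this assay.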